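The source may hold more compounds than are shown below. What is called first, only, known or untested is meant among the compounds shown, and "the series" means these compounds.

Measured compounds:
compound 1, `O=C(Cn1ccccc1=O)Nc1cc2ccccc2[nH]1`: > 67 ug/mL
compound 2, `CN(C)C(=O)c1cccc2ccccc12`: > 43 ug/mL

In a physicochemical assay for solubility, with a stated time of 24 h, at pH 6.8 (a lower number here means a less soluble compound, a higher number a more soluble compound), compound 1 gives > 67 ug/mL, which is a limit of the assay rather than a measured number. Compound 2 gives > 43 ug/mL in this assay, again only a limit. Compound 1 therefore stands at the limit of > 67 ug/mL in this assay, at which 1 of the 2 values shown sits, while the other value sits at the limit of > 43 ug/mL in this assay, at which 1 of the 2 values shown sits; since neither reading is a number, the two compounds cannot be placed in any order relative to each other. Compound 3, `Cn1c(NC(=O)Cn2ccccc2=O)cc2ccccc21`, has not yet been measured. Its difference from compound 1 is methyl in place of hydrogen on an aromatic nitrogen. Going by the values given here, no measured step between two compounds exists in this set, so no direction can be read from the data for this change. In this assay the expected step is an at least 1.1-fold lower number from compound 1 to compound 3 (0.04 log units; that floor lies within the scatter), which lies within the usual scatter. For compound 3 the estimated solubility is 60 ug/mL, with a range from 20 ug/mL to 150 ug/mL.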

Compound 3, solubility: 3 ug/mL
Beside the measured number, compound 3's estimate is 20-fold (1.30 log units) above it, outside the stated range (below it).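

Going by these compounds alone, this is the first step in the set that can be read: in this assay, methyl in place of hydrogen on an aromatic nitrogen gives an at least 22-fold lower number from compound 1 to compound 3 (1.34 log units; beyond the scatter). The change is small, just one heavy atom, yet at this position, on the nitrogen next to the ring atom that bears a large group, it is enough to turn a reading at the limit into a low measured number. Compound 1 stands only at a limit, so the step gives a floor and the real drop may be larger: the limit of > 67 ug/mL in this assay, at which 1 of the 3 values shown sits.

This single pair cannot separate the effect of losing the hydrogen from that of gaining the methyl. It also leaves open whether a longer chain on this nitrogen, or a chain ending in an amine, would give a similarly low reading.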